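Notes on adding a second trifluoromethyl group

The source may hold more compounds than are shown below. What is called first, only, known or untested is meant among the compounds shown, and "the series" means these compounds.

Compound 1 `CN(C(=O)NC(=O)c1ccc(Cl)cc1Cl)c1nc(C(F)(F)F)c(C(=O)N/N=C/c2cccc(C(F)(F)F)c2)s1` is the reference point of this set. In a functional assay on HeLa cells (Homo sapiens) for inhibition, read by MTT assay, with a stated time of 72 h (a lower number here means a stronger inhibitor, a higher number a weaker inhibitor), compound 1 gives 9.6 ug/mL. Compound 2 `CN(C(=O)NC(=O)c1ccc(Cl)cc1Cl)c1nc(C(F)(F)F)c(C(=O)N/N=C/c2cc(C(F)(F)F)cc(C(F)(F)F)c2)s1` carries one more trifluoromethyl group on the same ring; the difference is trifluoromethyl in place of hydrogen on an aromatic carbon. For compound 2 the result in this assay is a limit of the assay, > 100 ug/mL, and not a number. From the compounds shown here alone, the step is an at least 10-fold higher number from compound 1 to compound 2 (1.01 log units; beyond the scatter); the exact size is unknown because the value of compound 2 sits at the limit of > 100 ug/mL in this assay, at which 1 of the 3 values shown sits.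

Compound 3 `Cc1nc(N(C)C(=O)NC(=O)c2c(F)cccc2F)sc1C(=O)N/N=C/c1cccc(C(F)(F)F)c1` differs from compound 1 in its core; that difference is not broken down here. In this assay compound 3 gives 26.8 ug/mL, which is the higher of the two numbers measured in the set. Compound 4 `Cc1nc(N(C)C(=O)NC(=O)c2c(F)cccc2F)sc1C(=O)N/N=C/c1cc(C(F)(F)F)cc(C(F)(F)F)c1` has not been measured. It stands to compound 3 as compound 2 stands to compound 1: the change is trifluoromethyl in place of hydrogen on an aromatic carbon, and the surroundings of the position are described in the same words for both pairs, so it is the same change on a different core.

Among the compounds with values here, only one measured instance of this change exists, and it ends at a limit, so the expected step from compound 3 to compound 4 is taken as at least as large: a 9.3-fold higher number from compound 3 to compound 4 (0.97 log units; beyond the scatter) is the estimated step. Starting from compound 3, compound 4 is expected to give about 250 ug/mL in this assay, most likely reported only as a limit. The estimated range for compound 4 runs from 80 ug/mL to 800 ug/mL.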

Compound 4, half-maximal inhibitory concentration: 12.2 ug/mL
The estimate for compound 4 lay 20-fold (1.31 log units) above the measured number; measured number outside the range, below it.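

In this assay the added trifluoromethyl group gives a 2.2-fold lower number from compound 3 to compound 4 (0.34 log units; beyond the scatter), so the change does not run the same way on the two cores, and the steps clearly disagree: the same change on two cores in this assay, an at least 10-fold higher number (1.01 log units; beyond the scatter) from compound 1 to compound 2 and a 2.2-fold lower number (0.34 log units; beyond the scatter) from compound 3 to compound 4, at least 22-fold (1.35 log units) apart, beyond the scatter of two such steps. From the compounds shown here alone, compound 2 gives a limit and not a number, so the size of the step on the core of compound 1 stays open, although its direction can be read: the limit of > 100 ug/mL in this assay, at which 1 of the 4 values shown sits. Within the data shown here, this shows that, in this series, the step measured on one core could not be carried over to the other, but with only two pairs it does not show which of the differences between the cores goes with the reversal, and it gives no cause for it.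

The compounds shown leave open whether a single part of the core difference, either the trifluoromethyl group in place of the methyl on the shared core or the changed halogens on the benzoyl ring, is enough to turn the step around. They also leave open how the two cores respond when the second trifluoromethyl group is replaced by another group, such as a nitrile, a methoxy group, an amine or a carboxylic acid.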